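The source may hold more compounds than are shown below. What is called first, only, known or untested is meant among the compounds shown, and "the series" means these compounds.

Measured compounds and values: compound 1 `ClCc1ccccc1Cn1cnc2c(Cl)nc(Cl)nc21` gives 1380 nM; compound 2 `ClCc1ccccc1Cn1cnc2c(Cl)ncnc21` gives 7410 nM; compound 3 `ClCc1cccc(Cn2cnc3ncnc(Cl)c32)c1` gives 3380 nM. All three were run in a functional assay on MDA-MB-231 cells (Homo sapiens) for cytotoxicity, read by sulforhodamine B assay, with a stated time of 48 h; a higher number here means a weaker inhibitor of growth, a lower number a stronger inhibitor of growth.

Compounds 1 and 2 share a core and differ by one change, (chloro in place of hydrogen on an aromatic carbon). That change gave a 5.4-fold lower number from compound 2 to compound 1 (0.73 log units; beyond the scatter). Compound 3 carries a different core; the difference between the two cores is not broken down here. Within this assay compound 3 stands second highest of the three numbers, with compound 2 nearest and compound 1 furthest.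

Compound 4 `ClCc1cccc(Cn2cnc3nc(Cl)nc(Cl)c32)c1` has not been measured. It arises from compound 3 by chloro in place of hydrogen on an aromatic carbon, the same change that carries compound 2 to compound 1, since the two place descriptions agree word for word. The expectation for compound 4 therefore rests on a single measured example of this change. Compound 4 is expected to move from compound 3 by about a 4.8-fold lower number from compound 3 to compound 4 (0.68 log units; beyond the scatter), a step of roughly the size seen in a 5.4-fold lower number from compound 2 to compound 1 (0.73 log units; beyond the scatter). On that basis compound 4 is estimated at 700 nM in this assay, with a range from 300 nM to 1600 nM.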

Compound 4, concentration for total growth inhibition: 1730 nM
Estimate against measurement, compound 4: 2.5-fold (0.39 log units) below; measured number above the stated range.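

In this assay, chloro in place of hydrogen on an aromatic carbon gave a 2.0-fold lower number from compound 3 to compound 4 (0.29 log units; within the scatter), so on the core of compound 3 this step cannot be told apart from the scatter of repeated measurements. Set beside the earlier step, the change did not carry over from one core to the other at the same size: the same change on two cores in this assay, a 5.4-fold lower number (0.73 log units; beyond the scatter) from compound 2 to compound 1 and a 2.0-fold lower number (0.29 log units; within the scatter) from compound 3 to compound 4, 2.7-fold (0.44 log units) apart, beyond the scatter of two such steps. Among the compounds shown here, with only two pairs, this shows that the size of the step is not fixed across these compounds, but it does not show which feature of the two cores accounts for the gap, nor what the change would do on a third core.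

The compounds shown leave open how an amine, a methoxy group or a bromo would compare with chloro at the carbon that changes here. They also leave open what would follow if the chloromethyl group on the benzene ring gave way to a hydroxymethyl group or a plain methyl group.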